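The compounds below may be only part of what the source reports. "The series", "measured", "known", "first", "only" and "open" are said of these compounds alone.

Measured in a functional assay on the whole organism (strain Swiss albino) for inhibition, with Mus musculus as the target, in the writhing test, with stated times of 60 min and 15 min, at a dose of 100 mg/kg by the oral route; on this read-out higher numbers stand for more inhibition at the one dose given (going by the name of the read-out) and lower numbers for less inhibition:

compound 1 `CCNC(=O)CC1CCc2cc(OC)c(OC)cc21`: 23.6%
compound 2 `CCCCNC(=O)CC1CCc2cc(OC)c(OC)cc21`: 39.4%
compound 3 `COc1cc2c(cc1OC)C(CC(=O)NC(C)(C)C)CC2`: 41.8%

Compound 3 gives the highest of the three numbers; the nearest is a number 2.4 percentage points higher from compound 2 to compound 3 (within the scatter), the furthest a number 18.2 percentage points higher from compound 1 to compound 3 (beyond the scatter).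

Compound 4 `COc1cc2c(cc1OC)C(CC(=O)N1CCCCC1)CC2` differs from compound 3 by piperidin-1-yl in place of (tert-butyl)amino on a carbonyl carbon. Among the measured compounds shown here, the steps that bear on it are a number 15.8 percentage points higher from compound 1 to compound 2 (beyond the scatter) and a number 18.2 percentage points higher from compound 1 to compound 3 (beyond the scatter), each enlarging the group on the amide-type nitrogen, while a number 2.4 percentage points higher from compound 2 to compound 3 (within the scatter) shows that the two larger groups give similar numbers. For the measured compounds named here, no measured step removes the hydrogen-bond donor from the nitrogen, so that part of the change is uncovered by the series. In this assay the expected step is a number 3.8 percentage points lower from compound 3 to compound 4 (within the scatter), that is, none beyond the scatter. The estimate for compound 4 is 38%, within 22% to 52%.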

Compound 4, a percentage reported as inhibition, in the whole organism at one dose (the size of the read-out at that dose, not a potency): 44.7%
Beside the measured number, compound 4's estimate is 6.7 percentage points below it, and the stated range covers the measured number.
By their numbers in this assay, from the lowest: compound 1; then compounds 2, 3 and 4 (each within the scatter of the next).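

In this assay, piperidin-1-yl in place of (tert-butyl)amino on a carbonyl carbon gives a number 2.9 percentage points higher from compound 3 to compound 4 (within the scatter) and in place of butylamino gives a number 5.3 percentage points higher from compound 2 to compound 4 (within the scatter) so the amide hydrogen is not needed to reach this level at this dose. In place of ethylamino, the same group gives a number 21.1 percentage points higher from compound 1 to compound 4 (beyond the scatter) and thus only the ethyl amide stands apart from the other three. No supporting data explain these steps.

Going by these compounds, whether a pyrrolidin-1-yl or morpholin-4-yl ring on the carbonyl carbon holds this level remains open. A single dose also leaves the potency of these amides open.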